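Cytotoxicity on the step from compound 1 to compound 4

A few compounds are considered here, and "the series" means these few. Any claim that something is new, unique, unknown or untested is made for them only; others in the source may bear on it.

Three compounds built on one shared core were examined in an ADME assay on MT4 cells (Homo sapiens) for cytotoxicity, read by MTT assay, with a stated time of 4 days; a lower number here means that less compound is tolerated, a higher number that more compound is tolerated. Compound 1 `C/C(=N\NC(=O)COc1cccc2ccccc12)c1ccc(C#N)cc1Br` gives 12.1 ug/mL. Compound 2 `COc1cc(/C=N/NC(=O)COc2cccc3ccccc23)cc(OC)c1OC` gives 13.4 ug/mL, and compound 3 `O=C(COc1cccc2ccccc12)N/N=C/c1c(O)ccc2ccccc12` gives 2.12 ug/mL. Compound 1 therefore stands second highest of the three numbers: its nearest neighbour is compound 2, whose number sits within the usual scatter of that of compound 1, while the furthest is compound 3, whose lower number lies beyond the scatter.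

Compound 4 `C/C(=N\NC(=O)COc1cccc2ccccc12)c1ccccc1` has not yet been measured in this assay. It differs from compound 1 in a single place: phenyl in place of 2-bromo-4-cyanophenyl on a carbon with a double bond to nitrogen

Among the measured compounds shown here, no step between two measured compounds touches this same place, so there is no precedent in this set for the size of the change. What the data do show is that compound 1 and compound 2, which carry quite different groups at the corresponding position, return numbers within the scatter of each other, and only compound 3 falls clearly lower. On that basis compound 4 is expected to give about 15 ug/mL in this assay, with a range from 6 ug/mL to 40 ug/mL. The step of a 1.2-fold higher number from compound 1 to compound 4 (0.09 log units; within the scatter) is accordingly estimated to stay within the scatter, with at most a slight lean toward a higher number.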

Compound 4, half-maximal cytotoxic concentration: 105 ug/mL
Compound 4: the middle estimate sits 7.0-fold (0.85 log units) below what was measured; the whole stated range lies below it.
By their numbers in this assay, from the lowest: compound 3; then compounds 1 and 2 (each within the scatter of the next); then compound 4.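

The step at this position shows that the group on the carbon with a double bond to nitrogen can strongly shift the reading in this assay: replacing 2-bromo-4-cyanophenyl with phenyl gives an 8.7-fold higher number from compound 1 to compound 4 (0.94 log units; beyond the scatter). Among the compounds shown here, this is the first step in the set that can be read at this place, and it lies beyond the scatter, so the position is not indifferent to what it carries. Among the compounds shown, the unsubstituted phenyl of compound 4 goes with the most compound tolerated, while the change takes away the bromine and the cyano group together, so this one step cannot assign the shift to either of them. Nothing available here accounts for the size of this step.

The compounds shown leave open whether a phenyl carrying only the bromine or only the cyano group would stay close to compound 1 or to compound 4. They also leave open how this position would respond to a different group on the phenyl, such as an amine or a carboxylic acid.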